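Trifluoromethyl for fluoro on the aryl imine of the core

The compounds below may be only part of what the source reports. "The series", "measured", "known", "first", "only" and "open" are said of these compounds alone.

Measured so far:
compound 1, `Cc1nc2c([nH]1)C(=O)/C(=N/c1ccc(Cl)cc1Cl)C(Cl)=C2O`: 500 nM
compound 2, `Cc1nc2c([nH]1)C(=O)/C(=N/c1ccc(F)cc1)C(Cl)=C2O`: 1000 nM

Both numbers come from a functional assay on HUVEC cells (Homo sapiens) for antiproliferative activity; a lower number here means a stronger inhibitor, a higher number a weaker inhibitor. In this assay compound 2 gives 1000 nM and compound 1 gives 500 nM; the two values lie within the scatter of each other, so neither is set apart.

Compound 3, `Cc1nc2c([nH]1)C(=O)/C(=N/c1ccc(C(F)(F)F)cc1)C(Cl)=C2O`, carries the change (trifluoromethyl in place of fluoro on an aromatic carbon). Within the data shown here, no step between measured compounds informs this change, so a step of a 1.4-fold lower number from compound 2 to compound 3 (0.15 log units; within the scatter) is expected, essentially none beyond the scatter. Compound 3 is estimated at 700 nM, with a range from 250 nM to 2500 nM.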

Compound 3, half-maximal inhibitory concentration: 600 nM
Beside the measured number, compound 3's estimate is 1.2-fold (0.07 log units) above it; the measured number falls inside the stated range.
By their numbers in this assay, from the lowest: compounds 1, 3 and 2 (each within the scatter of the next).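

In this assay, trifluoromethyl in place of fluoro, on an aromatic carbon para to a large group, gives a 1.7-fold lower number from compound 2 to compound 3 (0.22 log units; within the scatter). Among these compounds, this position therefore takes a group of four heavy atoms in place of one with no change beyond the scatter, the first single-place comparison. No accompanying measurement speaks to the reason for this result.

Neither fluoro nor trifluoromethyl counts any hydrogen-bond donors or acceptors. On these data alone, whether an amine, a carboxylic acid or a longer chain at this position would move the number beyond the scatter remains open.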